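This account rests on a few compounds, and the source may have more. Where it says the series, first, only, none or still open, it means among the compounds named here.

Measured so far in this series:
compound 1 `O=C(/C(=C\c1ccc(Cl)cc1Cl)Sc1ccc(Br)cc1)c1ccc(Br)cc1`, 1000 nM
compound 2 `COc1ccccc1/C=C(/SCc1ccc(C)cc1)C(=O)c1ccc(Cl)cc1`, 10000 nM
compound 3 `COc1ccc(S/C(=C/c2ccc(Cl)cc2Cl)C(=O)c2ccc(Br)cc2)cc1`, 1000 nM

All three values come from a functional assay on DU-145 cells (Homo sapiens) for inhibition, read by trypan blue exclusion, with a stated time of 96 h; a higher number here means a weaker inhibitor of growth, a lower number a stronger inhibitor of growth. Compound 1 stands level with compound 3 at the digits shown, and these two share the lowest number of the set. Within the data shown here, compound 2 gives 10000 nM, a higher number than compound 1 at 1000 nM; the two differ at several places at once, so no single step can be drawn between them. Among the measured compounds shown here, the only single-point step in the set is no change at the digits printed from compound 1 to compound 3 (within the scatter), a change that sits on the aromatic ring attached to sulfur.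

The next compound is compound 4 `O=C(/C(=C\c1ccc(Br)cc1)Sc1ccc(Br)cc1)c1ccc(Br)cc1`. Its difference from compound 1 is 4-bromophenyl in place of 2,4-dichlorophenyl on a double-bonded chain carbon bound to a double-bonded chain carbon. For the measured compounds named here, this change sits on the double-bonded chain carbon, a place at which no measured step exists; the one measured step lies elsewhere and shows no change, and compound 2 cannot be used as a single step. There is therefore no measured basis for a direction. The step is expected to be a 1.5-fold higher number from compound 1 to compound 4 (0.18 log units; within the scatter), with a wide range to allow for the absence of direct precedent. For compound 4 the estimate in this assay is 1500 nM, expected to fall between 400 nM and 6000 nM.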

Compound 4, concentration for 50% growth inhibition: 1000 nM
For compound 4 the middle estimate is 1.5-fold (0.18 log units) above the measured one, within the range that was stated.
By their numbers in this assay, from the lowest: compounds 1, 3 and 4 (each within the scatter of the next); then compound 2.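

In this assay, among these compounds, the first measured step on a double-bonded chain carbon bound to a double-bonded chain carbon reads no change at the digits printed from compound 1 to compound 4 (within the scatter). At this place, therefore, 2,4-dichlorophenyl and 4-bromophenyl cannot be told apart by this read-out, and the halogen pattern of the aromatic group can change without a shift beyond the scatter; the earlier step, no change at the digits printed from compound 1 to compound 3 (within the scatter), spoke only to the aromatic ring attached to sulfur. Nothing available explains why the number holds across this change.

As far as these compounds go, both groups compared at this place are halogen-bearing phenyl rings, so the effect of an amine or a carboxylic acid on that ring, or of a longer chain in place of the ring, remains open. Compound 2, at 10000 nM, differs from compound 1 at several places at once, so it cannot show which of those places accounts for its higher number.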